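Side-chain change on the shared core: compound 3 to compound 4

This account rests on a few compounds, and the source may have more. Where it says the series, first, only, none or still open, it means among the compounds named here.

Measured compounds:
compound 1, `CC(C)=CC[C@@H](OC[C@H](C)O)C1=CC(=O)c2c(O)ccc(O)c2C1=O`: 24500 nM
compound 2, `COC(C)CO[C@H](CC=C(C)C)C1=CC(=O)c2c(O)ccc(O)c2C1=O`: 16600 nM
compound 3, `CC(=O)OC(C)CO[C@H](CC=C(C)C)C1=CC(=O)c2c(O)ccc(O)c2C1=O`: 16600 nM

In a functional assay on DU-145 cells (Homo sapiens) for cytotoxicity, read by MTT assay (on this read-out higher numbers stand for weaker inhibition and lower numbers for stronger inhibition), compound 1 gives 24500 nM, compound 2 gives 16600 nM and compound 3 gives 16600 nM. Compound 3 stands level with compound 2 at the digits reported, and the two together hold the lowest numbers of the three, though only by a margin within the scatter: a 1.5-fold lower number from compound 1 to compound 3 (0.17 log units; within the scatter), and no change at the digits printed from compound 2 to compound 3 (within the scatter).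

Compound 4, `CC(C)=CC[C@@H](OC(=O)c1ccoc1)C1=CC(=O)c2c(O)ccc(O)c2C1=O`, is not yet measured. It differs from compound 3 as follows: (furan-3-yl)carbonyl in place of 2-acetoxypropyl on an oxygen on a saturated carbon. For the measured compounds named here, the steps that bear on this change all act on the same oxygen on a saturated carbon: a 1.5-fold lower number from compound 1 to compound 2 (0.17 log units; within the scatter), a 1.5-fold lower number from compound 1 to compound 3 (0.17 log units; within the scatter), no change at the digits printed from compound 2 to compound 3 (within the scatter). None of them passes the scatter, and none involves a ring or a carbonyl in this position, so they give no direction for compound 4. The expectation for compound 4 in this assay is therefore a 1.1-fold lower number from compound 3 to compound 4 (0.04 log units; within the scatter), none beyond the scatter, with a wide range. Compound 4 is estimated at 15000 nM, between 5000 nM and 45000 nM.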

Compound 4, half-maximal inhibitory concentration: > 100000 nM
Compound 4: only a limit was reported (the forecaster's own chance of this, stated with the estimate: 5%); at least 6.6-fold (0.82 log units) between middle value and limit.
By their numbers in this assay, from the lowest: compounds 2, 3 and 1 (each within the scatter of the next). At a limit, above all of these: compound 4.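

In this assay compound 4 gives > 100000 nM, which is a limit of the assay and not a number. The values of compound 1, compound 2 and compound 3 lie within the scatter of each other, yet this position is not indifferent to every side chain: an at least 6.0-fold higher number from compound 3 to compound 4 (0.77 log units; beyond the scatter), an at least 6.0-fold higher number from compound 2 to compound 4 (0.77 log units; beyond the scatter), and an at least 4.0-fold higher number from compound 1 to compound 4 (0.61 log units; beyond the scatter). The change is therefore the first here to pass the scatter, and it places (furan-3-yl)carbonyl, with its five-membered aromatic ring and its carbonyl, on the oxygen on a saturated carbon.

The compounds shown do not separate the part played by the carbonyl from that of the ring; a plain acetyl or a benzoyl on this oxygen, or a furan-3-ylmethyl, would address that. Going by these compounds, how far the true value of compound 4 lies past its limit also remains open.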